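Thiocarbamate chromones: pyrrolidine in place of morpholine

A few compounds are considered here, and "the series" means these few. Any claim that something is new, unique, unknown or untested is made for them only; others in the source may bear on it.

Measured in a functional assay on HEp-2 cells (Homo sapiens) for antiproliferative activity, read by MTT assay, with a stated time of 72 h; on this read-out higher numbers stand for weaker inhibition and lower numbers for stronger inhibition:
compound 1 `O=c1cc(CSC(=S)N2CCCCC2)oc2cc(Cl)ccc12`: 1600 nM
compound 2 `O=c1c(CSC(=S)N2CCOCC2)coc2cc(Cl)ccc12`: 900 nM
compound 3 `Cc1ccc2c(=O)c(CSC(=S)N3CCOCC3)coc2c1`: 4000 nM

Compound 2 gives the lowest number of the three in this assay. Going by the values given here, compound 1 lies within the scatter of it, while compound 3 sits beyond it; the only single-place step in the set is a 4.4-fold higher number from compound 2 to compound 3 (0.65 log units; beyond the scatter), methyl in place of chloro on an aromatic carbon. Compound 4 `O=c1c(CSC(=S)N2CCCC2)coc2cc(Cl)ccc12` has not been measured. It differs from compound 2 by pyrrolidin-1-yl in place of morpholin-4-yl on a thiocarbonyl carbon.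

Among the compounds with values here, no measured step touches the amine on the thiocarbonyl carbon. Compound 1 and compound 2 differ both in the amine and in the point of attachment on the shared core, so their two values show only that they lie within the scatter of each other; nothing can be separated out for the amine alone. Within the data shown here, the one step beyond the scatter concerns the aromatic substituent, not the thiocarbonyl side, and does not bear on the present change. Both the ring leaving and the ring entering are non-aromatic amines, and with no evidence either way the expectation for compound 4 in this assay is a step of about no change at the digits printed from compound 2 to compound 4 (within the scatter), that is none beyond the scatter. Compound 4 is therefore estimated at 900 nM, with a range from 400 nM to 2000 nM.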

Compound 4, half-maximal inhibitory concentration: 2100 nM
The estimate for compound 4 lay 2.3-fold (0.37 log units) below the measured number; measured number outside the range, above it.
By their numbers in this assay, from the lowest: compounds 2, 1, 4 and 3 (each within the scatter of the next, the first and the last beyond it).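

Working notes on the amine: the thiocarbonyl carbon is now shown to be a position that responds in this assay, since pyrrolidin-1-yl in place of morpholin-4-yl gives a 2.3-fold higher number from compound 2 to compound 4 (0.37 log units; beyond the scatter). With a 4.4-fold higher number from compound 2 to compound 3 (0.65 log units; beyond the scatter) alongside it, both single-place steps away from compound 2 lead to a higher number, one on the thiocarbonyl side and one on the aromatic carbon, so compound 2 cannot be changed at either place, in these two ways, without a step beyond the scatter. Nothing at hand bears on why the amine change moves the number.

Whether the step follows the ring size or the presence of the ring oxygen stays unresolved, and compound 1 cannot settle this, as it differs from compound 2 both in the amine and in the point of attachment on the shared core. Also open, from the compounds shown here alone, is how a 4-methylpiperazin-1-yl ring or an open-chain diethylamino group on the same thiocarbonyl carbon would read in this assay, and whether any amine there gives a lower number than compound 2 does.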